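Benzyl to pyridinylmethyl swap on the ring amine

A few compounds are considered here, and "the series" means these few. Any claim that something is new, unique, unknown or untested is made for them only; others in the source may bear on it.

Compound 1 `CCCCNc1nc(N)nc2c1CN(Cc1ccccc1)CC2` carries a benzyl group and gives 0.06 uM in an assay on HEK293 cells for agonist activity at Toll-like receptor 8 (Homo sapiens), read by a luciferase reporter, with a stated time of 6 h; a higher number here means that more compound is needed for the effect, a lower number that less compound is needed. Going by the values given here, it holds the lowest of the two numbers measured so far. Among the compounds with values here, the nearest is compound 2 `CCCCNc1nc(N)nc2c1CCN(C)C2`, which gives 0.2 uM in this assay; the gap between the two values lies beyond the scatter, but the two structures differ in more than one place, so no single step is recorded for them. Compound 3 `CCCCNc1nc(N)nc2c1CN(Cc1ccncc1)CC2` is the next analogue and has not yet been measured in this assay. Relative to compound 1 the change is pyridin-4-yl in place of phenyl on a saturated chain carbon bound to an amine nitrogen in a ring. Keeping a six-membered aromatic ring while adding one hydrogen-bond acceptor is expected to leave the value near that of compound 1, with a step of a 1.2-fold lower number from compound 1 to compound 3 (0.08 log units; within the scatter) that may well fall within the scatter or run slightly lower. Compound 3 is therefore estimated at 0.05 uM, within a range of 0.02 uM to 0.15 uM.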

Compound 3, minimum effective concentration: 0.29 uM
Compound 3: middle estimate off by 5.8-fold (0.76 log units), on the low side; measured number outside the range, above it.
By their numbers in this assay, from the lowest: compound 1; then compounds 2 and 3 (each within the scatter of the next).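

In this assay, going by these compounds alone, pyridin-4-yl in place of phenyl gives a 4.8-fold higher number from compound 1 to compound 3 (0.68 log units; beyond the scatter), the first step that can be read at a single place, and it shows that the number responds to the aromatic ring on a saturated chain carbon bound to an amine nitrogen in a ring. Both groups are six-membered aromatic rings, so keeping that ring type does not by itself hold the value of compound 1 at 0.06 uM. Nothing available bears on the cause of this step.

From the compounds shown here alone, it remains open whether the step depends on the ring nitrogen as such or on where it sits, a question that pyridin-2-yl or pyridin-3-yl at this position would address. Also open, going by these compounds, is how 4-chlorophenyl, 4-methoxyphenyl or a longer chain carrying the phenyl would read against compound 1.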